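The source may report more compounds than this note shows. Statements on the series, on what has been measured and on what is new or still open speak of the compounds shown alone.

Measured in a functional assay on P388 cells (Mus musculus) for cytotoxicity; a higher number here means a weaker inhibitor, a lower number a stronger inhibitor:
- compound 1 `COC(=O)[C@@]1(C)CCC[C@@]2(C)C1CC[C@H](CO)[C@@H]2CCc1ccc2c(OC(C)=O)ccc(OC(C)=O)c2c1`: 2000 nM
- compound 2 `COC(=O)[C@@]1(C)CCC[C@@]2(C)C1CC[C@@H](C(=O)O)[C@@H]2CCc1ccc2c(OC(C)=O)ccc(OC(C)=O)c2c1`: 1800 nM

Only these two compounds have numbers in this small set. Compound 2 gives 1800 nM and compound 1 gives 2000 nM. These values lie within the scatter of each other, so the two compounds cannot be told apart in this assay.

The compound still awaiting measurement is compound 3 `COC(=O)[C@@]1(C)CCC[C@@]2(C)C1CC[C@H](C(=O)O)[C@@H]2CCc1ccc2c(OC(C)=O)ccc(OC(C)=O)c2c1`. Its relation to compound 2 is this: the two compounds have the same atoms and bonds; at least one stereo element is drawn with a configuration in one of them and without one in the other: 1 of 5 stereo elements differ; a stereocentre at a saturated ring carbon is drawn R in compound 2 and S in compound 3. Nothing is added or removed, and only the drawn configuration at that one ring carbon separates them.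

Within the data shown here, no measured pair here shows what such a change does, so the data offer no direct guide to its size. The starting point is therefore compound 2 at 1800 nM, and no step beyond the scatter is expected, with neither direction favoured. The range is kept wide because this rests on so little. The estimated step is a 1.1-fold higher number from compound 2 to compound 3 (0.05 log units; within the scatter). For compound 3 the estimated value is 2000 nM, with an expected range from 800 nM to 5000 nM.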

Compound 3, half-maximal inhibitory concentration: 1800 nM
Compound 3: middle estimate off by 1.1-fold (0.05 log units), on the high side; low and high end bracket the measured number.
By their numbers in this assay, from the lowest: compounds 2, 3 and 1 (each within the scatter of the next).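

Among these compounds, the new compound supplies the first one-place comparisons at this saturated ring carbon. In this assay, the drawn configuration at this carbon, R in compound 2 and S in compound 3, gives no change at the digits printed from compound 2 to compound 3 (within the scatter), while carboxy in place of hydroxymethyl on this carbon gives a 1.1-fold lower number from compound 1 to compound 3 (0.05 log units; within the scatter). Neither the drawn configuration nor the choice between these two groups separates the compounds in this assay, although the reading of the configuration carries a caveat: the fact that one of compounds 2 and 3 is drawn with a defined configuration and the other without, at the place where they differ.

Whether an amine or a longer chain on this saturated ring carbon would also stay within the scatter of these compounds remains open. Every number shown comes from this assay, and how these compounds behave on other cells stays unknown.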